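This account rests on a few compounds, and the source may have more. Where it says the series, first, only, none or still open, it means among the compounds named here.

For the measured compounds named here, compound 1, `COc1cc2c(cc1OC)C(=O)/C(=C/c1ccc(CN(C)Cc3ccccc3)c(O)c1)O2`, is one of two compounds measured in an assay on cells for inhibition of Amine oxidase [flavin-containing] A (Homo sapiens), read by fluorescence, with a stated time of 30 min, tested at 10 uM; on this read-out lower numbers stand for less inhibition and higher numbers for more inhibition at the one concentration tested (going by the name of the read-out). In this assay compound 1 gives 19.4%. Going by the values given here, the only other measured compound, compound 2, `COc1cc2c(cc1OC)C(=O)/C(=C/c1ccc(CN3CCN(Cc4ccccc4)CC3)c(O)c1)O2`, gives 15.3% in this assay. The two numbers differ by an amount that lies within the usual scatter of this kind of measurement, so nothing can be said about an order between compound 1 and compound 2; both sit at modest inhibition at the single concentration tested.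

Compound 3, `COc1cc2c(cc1OC)C(=O)/C(=C/c1cccc(O)c1)O2`, has not yet been measured in this assay. It differs from compound 1 in one place: hydrogen in place of (benzyl(methyl)amino)methyl on an aromatic carbon. Among the compounds with values here, no step between measured compounds isolates such a change, so the expectation for compound 3 rests only on the two measured numbers and on the size of the group that leaves. The step of a number 8.4 percentage points lower from compound 1 to compound 3 (within the scatter) is expected to be small and downward, probably not far beyond the scatter. Compound 3 is accordingly expected to give about 11% in this assay, with a plausible range from 0% to 25%.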

Compound 3, a percentage reported as inhibition, at one concentration (the size of the read-out at that concentration, not a potency): 17.2%
Compound 3: the middle estimate sits 6.2 percentage points below what was measured, and the stated range covers the measured number.
By their numbers in this assay, from the lowest: compounds 2, 3 and 1 (each within the scatter of the next).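

With hydrogen in place of (benzyl(methyl)amino)methyl on the aromatic carbon ortho to a hydroxy group, this assay gives a number 2.2 percentage points lower from compound 1 to compound 3 (within the scatter), so this group of 10 heavy atoms, with its six-membered aromatic ring and its nitrogen, makes no difference that can be told from the scatter. The earlier compounds shown here both carried a large amine-bearing group at this place and could not show what the unsubstituted position gives; compound 3 shows that modest inhibition at the single concentration tested persists without any such group. No measurement shown here offers an explanation for this result.

The compounds shown leave open whether any other group at this position would give a clearly higher number in this assay, such as a small dimethylaminomethyl group, a carboxylic acid or a halogen such as chlorine. For the compounds shown here, they also leave open what the hydroxy group contributes, since no compound here carries a methoxy group or hydrogen in its place, and a single-concentration reading gives no potency for any of them.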